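A few compounds are considered here, and "the series" means these few. Any claim that something is new, unique, unknown or untested is made for them only; others in the source may bear on it.

Three compounds were measured, all in a functional assay on HCC 2998 cells (Homo sapiens) for cytotoxicity, read by sulforhodamine B assay, with a stated time of 48 h; a lower number here means a stronger inhibitor of growth, a higher number a weaker inhibitor of growth: compound 1 `ClCc1ccccc1Cn1cnc2c(Cl)nc(Cl)nc21` gave 3380 nM; compound 2 `ClCc1ccccc1Cn1cnc2c(Cl)ncnc21` gave 3540 nM; compound 3 `ClCc1cccc(Cn2cnc3ncnc(Cl)c32)c1` gave 3230 nM.

Compound 2 and compound 1 differ in one place: chloro in place of hydrogen on an aromatic carbon. That change gave a 1.0-fold lower number from compound 2 to compound 1 (0.02 log units; within the scatter). Compound 3 has the same atoms as compound 2 joined differently; the difference between the two cores is not broken down here. The values of compound 3, compound 1 and compound 2 all lie within the scatter of one another.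

Compound 4 `ClCc1cccc(Cn2cnc3nc(Cl)nc(Cl)c32)c1` is not yet measured. It differs from compound 3 in the same way: chloro in place of hydrogen on an aromatic carbon. Because the same change gave a 1.0-fold lower number from compound 2 to compound 1 (0.02 log units; within the scatter), the step is expected to be a 1.0-fold higher number from compound 3 to compound 4 (0.01 log units; within the scatter) in this assay. In this assay compound 4 is therefore estimated at 3300 nM, with a likely range from 1700 nM to 6500 nM.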

Compound 4, concentration for total growth inhibition: 3310 nM
Compound 4: the middle estimate sits 1.0-fold (0.00 log units) below what was measured; measured number inside the range.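

In this assay, chloro in place of hydrogen on the aromatic carbon between two ring nitrogen atoms gave a 1.0-fold higher number from compound 3 to compound 4 (0.01 log units; within the scatter). The change therefore reads the same on both cores: the same change on two cores in this assay, a 1.0-fold lower number (0.02 log units; within the scatter) from compound 2 to compound 1 and a 1.0-fold higher number (0.01 log units; within the scatter) from compound 3 to compound 4, 1.1-fold (0.03 log units) apart, within the scatter of two such steps. This shows only that the change left no readable mark on either of these two cores in this one cell assay; it does not show that the same would hold on another core or in another assay, and with no step beyond the scatter, no real effect has been shown to carry over.

The compounds shown hold only hydrogen or chloro at that carbon, so how an amine or a methoxy group there would read in this assay remains open. Also open, on these data alone, is what a hydroxymethyl group would do in place of the chloromethyl group.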